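The source may hold more compounds than are shown below. What is called first, only, known or untested is meant among the compounds shown, and "the series" means these compounds.

Measured so far in a functional assay on HEK293 cells for antagonist activity at transient receptor potential cation channel subfamily V member 1 (Rattus norvegicus), read by calcium flux; a higher number here means a weaker inhibitor, a lower number a stronger inhibitor: compound 1 `Cc1ccc(Nc2ncnc3sc(Nc4c(Cl)cccc4Cl)nc23)cc1` gives 32 nM; compound 2 `CS(=O)(=O)c1ccc(Nc2ncnc3sc(Nc4c(Cl)cccc4Cl)nc23)cc1` gives 3 nM.

Among the compounds with values here, compound 2 holds the lower of the two numbers, and the single measured step, an 11-fold lower number from compound 1 to compound 2 (1.03 log units; beyond the scatter), is large. Compound 3 `O=S(=O)(c1ccc(Nc2ncnc3sc(Nc4c(Cl)cccc4Cl)nc23)cc1)N1CCCC1` differs from compound 2 by pyrrolidin-1-yl in place of methyl on a sulfonyl sulfur. Within the data shown here, no measured step changes what sits on the sulfonyl sulfur, so the one step available only shows that this part of the molecule can matter. Since the sulfonyl itself stays, compound 3 is expected to land near compound 2, estimated at 5 nM, between 1.5 nM and 20 nM, a step of a 1.7-fold higher number from compound 2 to compound 3 (0.22 log units; within the scatter) inside the scatter.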

Compound 3, half-maximal inhibitory concentration: 0.5 nM
For compound 3 the middle estimate is 10-fold (1.00 log units) above the measured one; the measured number lies below the stated range.
By their numbers in this assay, from the lowest: compound 3; then compound 2; then compound 1.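

With the sulfonyl kept, this assay still records a 6.0-fold lower number from compound 2 to compound 3 (0.78 log units; beyond the scatter) when pyrrolidin-1-yl replaces methyl on the sulfonyl sulfur, so what sits on that sulfur matters, not the sulfonyl alone. The full change on the aromatic carbon, methyl to (pyrrolidin-1-yl)sulfonyl, gives a 64-fold lower number from compound 1 to compound 3 (1.81 log units; beyond the scatter) overall. Nothing measured here gives a reason for either step.

On these data alone, whether the ring itself counts remains open: a piperidine ring, a morpholine ring or an open-chain diethylamino group on the same sulfur could tell ring from chain.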